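The compounds below may be only part of what the source reports. "The series", "measured", "known", "first", "only" and "open" are said of these compounds alone.

Compound 1 `O=C(O)Cn1nc(Cc2nc3cc(Cl)c(OCC(F)F)cc3[nH]2)c2ccccc2c1=O`: in an ADME assay on microsomes from liver (Mus musculus) for metabolic stability (a higher number here means faster removal of the compound, a lower number slower removal), compound 1 gives < 56.7 mL/min/kg, a limit of the assay and not a number.
Compound 2 `C[C@@H](C(=O)O)c1nn(Cc2cn3cc(OCC4CC4)c(Cl)cc3n2)c2ccccc2c1=O`: in this assay compound 2 gives < 55 mL/min/kg, again a limit of the assay.
Compound 3 `CCn1nc(CC(=O)Nc2ccc(OC(F)(F)F)c(Cl)c2)c2ccccc2c1=O`: in this assay compound 3 gives 81.7 mL/min/kg.

Compound 2 stands at the limit of < 55 mL/min/kg in this assay, at which 1 of the 3 values shown sits, so only an upper bound is known for it. Compound 1 rests at the limit of < 56.7 mL/min/kg in this assay, at which 1 of the 3 values shown sits. Within the data shown here, of the three compounds, only compound 3 carries a measured number, and no step between measured compounds that differ in one place is available, so no measured step can guide the next change.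

Compound 4 `O=C(O)C1(c2nn(Cc3cn4cc(OCC5CC5)c(Cl)cc4n3)c3ccccc3c2=O)CC1` is the unmeasured analogue of compound 2. The change is 1-carboxycyclopropyl in place of 1-carboxyethyl on an aromatic carbon. The two acids keep the same hydrogen-bond donor and acceptor count, and the core of compound 2 is untouched.

Among the measured compounds shown here, with no measured step to draw on, the expectation is a step of no size beyond the scatter, in either direction. Compound 4 is therefore expected to sit near the same bound as compound 2, with the step that the limit leaves unreadable from compound 2 to compound 4 estimated as small. The estimate for compound 4 in this assay is 45 mL/min/kg, within a range from 20 mL/min/kg to 80 mL/min/kg, and it is thought likely that the assay again reports only a limit.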

Compound 4, clearance: < 53.4 mL/min/kg
Compound 4 ended at the assay's limit (the forecaster's own chance of this, stated with the estimate: 60%); the middle value is on the limit's open side.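

In this assay compound 4 gives < 53.4 mL/min/kg, a limit of the assay and not a number. Among these compounds, compound 2 also rests at a limit, so no step between compound 2 and compound 4 can be read. The compounds shown leave open what clearance values lie behind these two limits, and whether 1-carboxycyclopropyl in place of 1-carboxyethyl changes clearance at all.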